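Allyl-substituted series: ortho-chloro arylidene, expected cytotoxicity

This account rests on a few compounds, and the source may have more. Where it says the series, first, only, none or still open, it means among the compounds named here.

Compounds measured so far:
Compound 1, `C=CCn1c(=O)/c(=C\c2cccc(Br)c2)[nH]c(=O)/c1=C\c1ccccc1OC`: 5900 nM
Compound 2, `C=CCn1c(=O)/c(=C\c2cccc(Cl)c2)[nH]c(=O)/c1=C\c1ccccc1OC`: 4600 nM
Compound 3, `C=CCn1c(=O)/c(=C\c2ccc(C)cc2)[nH]c(=O)/c1=C\c1ccccc1OC`: "not active" (no number reported), without a number

In a functional assay on BGC-823 cells (Homo sapiens) for cytotoxicity, read by CCK-8 assay, with a stated time of 72 h (a higher number here means a weaker inhibitor, a lower number a stronger inhibitor), compound 1 gives 5900 nM and compound 2 gives 4600 nM. Among the measured compounds shown here, the one step between them, chloro in place of bromo on an aromatic carbon, was a 1.3-fold lower number from compound 1 to compound 2 (0.11 log units; within the scatter). Compound 3 stands apart: in this assay compound 3 is reported only as "not active" (no number reported), so no number places it against compound 1 or compound 2.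

Compound 4, `C=CCn1c(=O)/c(=C\c2ccccc2Cl)[nH]c(=O)/c1=C\c1ccccc1OC`, is not yet measured. Against compound 3 the change is 2-chlorophenyl in place of 4-methylphenyl on a double-bonded chain carbon bound to an aromatic carbon. For the measured compounds named here, no measured step bears on this change directly; the only measured step concerns an exchange of one halogen for another and lies within the scatter, and compound 3 itself has no number to step from. What the series shows is that the two halogen-bearing compounds 1 and 2 give numbers while the methyl-bearing compound 3 gives none. On that basis compound 4, which carries a chlorine, is expected to return a number in this assay, estimated near 8000 nM with a range of 2000 nM to 40000 nM, though the chance of a limit rather than a number is not small.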

Compound 4, half-maximal inhibitory concentration: 4600 nM
Estimate against measurement, compound 4: 1.7-fold (0.24 log units) above; the measured number falls inside the stated range.
By their numbers in this assay, from the lowest: compounds 2, 4 and 1 (each within the scatter of the next).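

In this assay, 2-chlorophenyl in place of 3-chlorophenyl on a double-bonded chain carbon bound to an aromatic carbon gives no change at the digits printed from compound 2 to compound 4 (within the scatter), and 2-chlorophenyl in place of 3-bromophenyl gives a 1.3-fold lower number from compound 1 to compound 4 (0.11 log units; within the scatter), so the chlorine's placement on this phenyl group, like the earlier exchange of halogen, does not separate these compounds. Compound 4 returns a number while compound 3 is reported only as "not active", but the change from 4-methylphenyl to 2-chlorophenyl cannot be read as a step without a number for compound 3. No measurement at hand accounts for these results.

Open, going by these compounds, is whether the missing number for compound 3 goes with its methyl group or with where that group sits, which 4-chlorophenyl or 2-methylphenyl at this place would help separate. Also open, on these data alone, is how this place responds to a group outside this set, such as an amine or a carboxylic acid.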